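Replacing the Dichlorophenyl Tail with a Trifluoromethylphenyl

A few compounds are considered here, and "the series" means these few. Any claim that something is new, unique, unknown or untested is made for them only; others in the source may bear on it.

Compound 1, `COc1cc(Cl)cc(-c2nn(-c3cccc(NC(=O)Nc4ccc(Cl)c(C(F)(F)F)c4)c3)cc2-c2ccncc2)c1`, gives -81% in a functional assay on 786-0 cells (Homo sapiens) for inhibition, read by sulforhodamine B assay, with a stated time of 48 h, tested at 100 uM; a higher number here means a weaker effect of the compound at the concentration tested, a lower number a stronger effect.
Compound 2, `COc1cc(Cl)cc(-c2nn(-c3cccc(NC(=O)Nc4cc(C(F)(F)F)cc(C(F)(F)F)c4)c3)cc2-c2ccncc2)c1`, gives -70%.
Compound 3, `COc1cc(Cl)cc(-c2nn(-c3cccc(NC(=O)Nc4ccc(Cl)c(Cl)c4)c3)cc2-c2ccncc2)c1`, gives -46%.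

On these numbers compound 3 stands highest of the three, meaning the weakest effect at the concentration tested; compound 2 is nearest to it and compound 1 furthest, and both gaps lie beyond the scatter. Compound 4, `COc1cc(Cl)cc(-c2nn(-c3cccc(NC(=O)Nc4cccc(C(F)(F)F)c4)c3)cc2-c2ccncc2)c1`, has not yet been measured. It differs from compound 3 at the urea end of the molecule: 3-(trifluoromethyl)phenyl in place of 3,4-dichlorophenyl on an amide-type nitrogen.

One measured step speaks to this change: a number 35 percentage points higher from compound 1 to compound 3 (beyond the scatter). Compound 4 undoes that swap, bringing a trifluoromethyl group back onto the terminal ring, while also leaving out the second chloro that compound 1 carries. Compound 2, whose terminal ring holds two trifluoromethyl groups and no chloro, also sits well below compound 3. The move from compound 3 to compound 4 is therefore expected to run downward, toward a stronger effect, by an amount beyond the scatter, roughly a number 19 percentage points lower from compound 3 to compound 4 (beyond the scatter). For compound 4 the estimate in this assay is -65%, with a likely range from -85% to -35%.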

Compound 4, a percentage reported as activity, at one concentration (the size of the read-out at that concentration, not a potency): -57%
Compound 4: the middle estimate sits 8 percentage points below what was measured, within the range that was stated.
By their numbers in this assay, from the lowest: compound 1; then compound 2; then compound 4; then compound 3.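

In this assay, the exchange of 3,4-dichlorophenyl for 3-(trifluoromethyl)phenyl on the amide-type nitrogen gives a number 11 percentage points lower from compound 3 to compound 4 (beyond the scatter), so one trifluoromethyl group with no chloro on the ring gives a stronger effect than two chloro groups. Compound 4 also shows what the second group on the terminal ring contributes, since hydrogen in place of trifluoromethyl gives a number 13 percentage points higher from compound 2 to compound 4 (beyond the scatter) and hydrogen in place of chloro gives a number 24 percentage points higher from compound 1 to compound 4 (beyond the scatter); among these three trifluoromethyl compounds, the two with a second group are both stronger, and the chloro partner goes with the larger step. Nothing measured here explains why these groups rank as they do.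

As far as these compounds go, it remains open whether this ranking depends on halogen-bearing groups at all, as a nitrile, an amine or a carboxylic acid on the terminal ring might rank anywhere relative to these compounds. From the compounds shown here alone, each value is also the size of the read-out at a single concentration rather than a potency, so how far these differences would hold at other concentrations is still unknown.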